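The source may report more compounds than this note shows. Statements on the series, on what has been measured and on what is new or still open speak of the compounds shown alone.

Compound 3 `CCOC(=O)c1ccc(Nc2nccc(-c3cccnc3)n2)cc1` gives 12400 nM in a functional assay for inhibition, with Homo sapiens as the target (a lower number here means a stronger inhibitor, a higher number a weaker inhibitor), the highest number of the three measured. Compound 1 `CC(=O)N(C)c1ccc(Nc2nccc(-c3cccnc3)n2)cc1` gives 900 nM and compound 2 `c1cncc(-c2ccnc(Nc3ccc(-n4ccnc4)cc3)n2)c1` gives 1300 nM; the step of a 1.4-fold higher number from compound 1 to compound 2 (0.16 log units; within the scatter) stays within the scatter. Against both, compound 3 stands apart: a 14-fold higher number from compound 1 to compound 3 (1.14 log units; beyond the scatter) and a 9.5-fold higher number from compound 2 to compound 3 (0.98 log units; beyond the scatter) are beyond the scatter, making it the weakest of the three. Compound 4 `CC(C)(C)c1ccc(Nc2nccc(-c3cccnc3)n2)cc1` is not yet measured; the change is tert-butyl in place of ethoxycarbonyl on an aromatic carbon. The two steps that bear on it both run toward the ethoxycarbonyl compound and both raised the number, so exchanging that group is expected to lower the number by roughly their size. Compound 4 is therefore expected at 1500 nM, with a range from 400 nM to 6000 nM, an expected step of an 8.3-fold lower number from compound 3 to compound 4 (0.92 log units; beyond the scatter).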

Compound 4, half-maximal inhibitory concentration: 600 nM
Estimate against measurement, compound 4: 2.5-fold (0.40 log units) above; the range from low to high includes it.
By their numbers in this assay, from the lowest: compounds 4, 1 and 2 (each within the scatter of the next, the first and the last beyond it); then compound 3.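

In this assay, among the compounds shown here, a group of carbon only can fill this place, para to a large group: a 21-fold lower number from compound 3 to compound 4 (1.32 log units; beyond the scatter), and this is the largest step so far. For the compounds shown here, compound 4 also matches the acetyl(methyl)amino compound, with a 1.5-fold lower number from compound 1 to compound 4 (0.18 log units; within the scatter), while a 2.2-fold lower number from compound 2 to compound 4 (0.34 log units; beyond the scatter) is a modest gain over the 1H-imidazol-1-yl compound, which leaves ethoxycarbonyl as the only group of the four that stands apart. No measurement at hand explains these differences.

Open, on these data alone, is how a carboxylic acid, a primary amine or a small methyl group would read at this place. Also open, as far as these compounds go, is whether a longer alkyl chain would match tert-butyl.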